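The source may report more compounds than this note shows. Statements on the series, on what has been measured and on what is new or still open speak of the compounds shown alone.

Measured compounds:
Compound 1, `CC(C)(N)C(=O)N[C@H](COCc1ccccc1C(F)(F)F)c1nnnn1CCOC(=O)NCCCCO`: 0.72 nM
Compound 2, `CC(C)(N)C(=O)N[C@H](COCC1CCCCC1)c1nnnn1CCOC(=O)NCCCCO`: 1.66 nM

Compound 1 stands lowest of the two numbers in a functional assay on cells for inhibition of growth hormone secretagogue receptor type 1 (Homo sapiens), read by FLIPR and calcium flux; a higher number here means that more compound is needed for the effect, a lower number that less compound is needed; its nearest neighbour is compound 2, and the step of a 2.3-fold higher number from compound 1 to compound 2 (0.36 log units; beyond the scatter) was a modest one, made by putting cyclohexyl in place of 2-(trifluoromethyl)phenyl on a saturated chain carbon bound to an oxygen on a saturated carbon.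

Compound 3, `Cc1noc(C)c1-c1ccccc1COC[C@@H](NC(=O)C(C)(C)N)c1nnnn1CCOC(=O)NCCCCO`, is not yet measured. It differs from compound 1 as follows: 3,5-dimethyl-1,2-oxazol-4-yl in place of trifluoromethyl on an aromatic carbon. The aromatic ring is kept here; only the group on it is exchanged. Among the compounds with values here, no measured step bears directly on this exchange, since the single step at hand replaced the whole ring rather than the trifluoromethyl on it. The expectation is therefore a step no larger than the scatter, a 1.4-fold higher number from compound 1 to compound 3 (0.14 log units; within the scatter), with wide uncertainty. Compound 3 is estimated at 1 nM, within 0.3 nM to 3.5 nM.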

Compound 3, half-maximal effective concentration: 1.04 nM
Compound 3: the middle estimate sits 1.0-fold (0.02 log units) below what was measured, within the range that was stated.
By their numbers in this assay, from the lowest: compounds 1, 3 and 2 (each within the scatter of the next, the first and the last beyond it).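

In this assay, exchanging trifluoromethyl for 3,5-dimethyl-1,2-oxazol-4-yl on this aromatic carbon, ortho to a large group, gives a 1.4-fold higher number from compound 1 to compound 3 (0.16 log units; within the scatter), so the two compounds cannot be told apart here. The earlier step replaced the whole aromatic ring, whereas this one keeps the ring and shows that a group of 7 heavy atoms with a five-membered aromatic ring and 2 hydrogen-bond acceptors can stand where a group of 4 heavy atoms with no acceptors stood, without a change beyond the scatter. Nothing measured here explains this outcome. Going by these compounds, whether the same carbon would accept an amine, a carboxylic acid or simply a hydrogen stays open. Also open, on these data alone, is whether the two methyl groups on the 3,5-dimethyl-1,2-oxazol-4-yl matter to the number.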